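A carbamoyl swap on compound 3

The compounds below may be only part of what the source reports. "The series", "measured", "known", "first", "only" and "open" are said of these compounds alone.

In a functional assay on HepG2 cells (Homo sapiens) for inhibition, read by MTT assay, with a stated time of 48 h (a lower number here means a stronger inhibitor, a higher number a weaker inhibitor), compound 2 `COc1cc(-c2nnc(SCc3ccc(F)cc3)n2-c2ccc(N(C)C)cc2)cc(OC)c1OC` gives 26400 nM and compound 3 `COc1ccc(C(=O)CSc2nnc(-c3cc(OC)c(OC)c(OC)c3)n2-c2ccc(N(C)C)cc2)cc1` gives 18800 nM. These two values lie within the scatter of each other, so compound 3 holds the lowest number shown only nominally. Compound 1 `COc1ccc(-n2c(SCC(=O)Nc3ccc(Cl)cc3)nnc2-c2cc(OC)c(OC)c(OC)c2)cc1`, which carries a (4-chlorophenyl)carbamoyl group, reports only a limit in this assay, > 60000 nM.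

Compound 4 `COc1cc(-c2nnc(SCC(=O)Nc3ccc(Cl)cc3)n2-c2ccc(N(C)C)cc2)cc(OC)c1OC` is reached from compound 3 by one change on a carbonyl carbon, where (4-chlorophenyl)amino takes the place of 4-methoxyphenyl: (4-chlorophenyl)amino in place of 4-methoxyphenyl on a carbonyl carbon. The same difference, read one bond further out, is (4-methoxyphenyl)carbonyl to (4-chlorophenyl)carbamoyl.

For the measured compounds named here, only one measured step touches this part of the structure. It is a 1.4-fold lower number from compound 2 to compound 3 (0.15 log units; within the scatter), with (4-methoxyphenyl)carbonyl in place of 4-fluorophenyl on a saturated chain carbon bound to a sulfur, and it stays within the scatter. This step from compound 2 suggests a small size, while compound 1, at the limit of > 60000 nM in this assay, at which 1 of the 3 values shown sits, gives a weak lean toward a higher number. The expected step is a 1.6-fold higher number from compound 3 to compound 4 (0.20 log units; within the scatter), so nothing clearly beyond the scatter is anticipated. For compound 4 the estimated value is 30000 nM, expected to fall between 11000 nM and 70000 nM.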

Compound 4, half-maximal inhibitory concentration: > 60000 nM
Compound 4 was reported as a limit; the forecaster's own chance of this, stated with the estimate: 30%; at least 2.0-fold (0.30 log units) between middle value and limit.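

In this assay, for the compounds shown here, putting (4-chlorophenyl)amino in place of 4-methoxyphenyl on a carbonyl carbon gives an at least 3.1-fold higher number from compound 3 to compound 4 (0.50 log units; beyond the scatter), the first change in this part of the structure to clear the scatter, whereas the earlier 1.4-fold lower number from compound 2 to compound 3 (0.15 log units; within the scatter) did not. The (4-chlorophenyl)carbamoyl group also separates from 4-fluorophenyl on a saturated chain carbon bound to a sulfur, with an at least 2.2-fold higher number from compound 2 to compound 4 (0.35 log units; beyond the scatter), so of the three groups compared here it alone stands apart, and because compound 4 is a limit, both steps give only a minimum size. Compound 1 and compound 4 share this group and both stand at a limit, so the step between them, dimethylamino in place of methoxy on an aromatic carbon, cannot be read: the limit of > 60000 nM in this assay, at which 2 of the 4 values shown sit.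

How far the true value of compound 4 lies beyond its limit remains unknown, and the compounds shown do not separate the part played by the amide hydrogen from that of the chlorine. Going by these compounds, whether a plain phenylamino group, a methylamino group or a hydroxyl group on this carbonyl carbon would stay level with compound 3 also remains open.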